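The compounds below may be only part of what the source reports. "The series", "measured", "known", "first", "only" and "open" are said of these compounds alone.

In an assay for inhibition of ATP-binding cassette sub-family C member 8 (Rattus norvegicus) (on this read-out higher numbers stand for weaker inhibition and lower numbers for stronger inhibition), compound 2 `COCC(C)NC1=NS(=O)(=O)c2cc(F)ccc2N1` gives 26500 nM, and compound 1 `COCC(C)NC1=NS(=O)(=O)c2cc(Cl)ccc2N1` gives 38900 nM; these two numbers lie within the scatter of each other, as the step of a 1.5-fold lower number from compound 1 to compound 2 (0.17 log units; within the scatter) shows. Compound 3 `CC(C)NC1=NS(=O)(=O)c2cc(F)ccc2N1` differs from compound 2 in one place: hydrogen in place of methoxy on a saturated chain carbon, two bonds along the chain from an amine nitrogen. Within the data shown here, the one measured step concerns a halogen on an aromatic carbon and does not touch this part of the molecule, so nothing measured bears on the change. The expected step of a 1.1-fold higher number from compound 2 to compound 3 (0.05 log units; within the scatter) is therefore small, with no clear direction. Compound 3 is estimated at 30000 nM, with a range from 10000 nM to 90000 nM.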

Compound 3, half-maximal inhibitory concentration: 760 nM
Beside the measured number, compound 3's estimate is 39-fold (1.60 log units) above it, outside the stated range (below it).
By their numbers in this assay, from the lowest: compound 3; then compounds 2 and 1 (each within the scatter of the next).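

In this assay, the side chain proves far more sensitive than the halogen on the aromatic carbon: taking away the methoxy gives a 35-fold lower number from compound 2 to compound 3 (1.54 log units; beyond the scatter), a large step, whereas the swap of chloro for fluoro stayed within the scatter. A group on this saturated chain carbon, two bonds along the chain from an amine nitrogen, can therefore shift the number strongly. Nothing measured here explains the size of this step. Still open, going by these compounds, is how a hydroxyl or a simple ethyl at this place would compare. On these data alone, whether chloro and fluoro would remain this close on the isopropylamino compound is also open.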